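The source may report more compounds than this note shows. Statements on the series, on what has been measured and on what is new or still open speak of the compounds shown alone.

Working notes on the series.

Activity is read in a functional assay on HeLa cells (Homo sapiens) for cytotoxicity, read by MTT assay, with a stated time of 72 h; a higher number here means a weaker inhibitor, a lower number a stronger inhibitor. Compound 1 `COc1ccc(C(=O)O[C@H]2C=C(C)C(=O)C[C@@]3(C)CC[C@@](O)(C(C)C)[C@H]23)cc1` gives 29700 nM in this assay. Compound 2 `CC1=C[C@H](OC(=O)c2ccc(O)cc2)[C@@H]2[C@](C)(CC[C@@]2(O)C(C)C)CC1=O` gives 26100 nM in this assay. Going by the values given here, the single change between them is hydrogen in place of methyl on an oxygen on an aromatic ring, and the step is a 1.1-fold lower number from compound 1 to compound 2 (0.06 log units; within the scatter); the two values sit together within the usual scatter, so no direction is read from this pair.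

Compound 3 `COc1ccc(C(=O)O[C@H]2CC(C)=CC[C@@]3(C)CC[C@@](O)(C(C)C)[C@H]23)cc1` returns only a limit, > 100000 nM in this assay, and the limit of > 100000 nM in this assay, at which 1 of the 3 values shown sits, marks where it sits. The difference between the core of compound 3 and the core of compound 1 is not broken down here.

Compound 4 `CC1=CC[C@@]2(C)CC[C@@](O)(C(C)C)[C@@H]2[C@@H](OC(=O)c2ccc(O)cc2)C1` is not yet measured. It differs from compound 3 by hydrogen in place of methyl on an oxygen on an aromatic ring, the same change as that from compound 1 to compound 2, at the same place. On the strength of that earlier step, a 1.1-fold lower number from compound 1 to compound 2 (0.06 log units; within the scatter), the expected step from compound 3 to compound 4 is small, a step that the limit leaves unreadable from compound 3 to compound 4, and since compound 3 is known only as a limit, compound 4 is expected to sit near that same limit in this assay, estimated at 150000 nM, with a range of 60000 nM to 400000 nM expected.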

Compound 4, half-maximal inhibitory concentration: > 100000 nM
Compound 4: a limit, no number; the forecaster's own chance of this, stated with the estimate: 70%; the middle value lies beyond the limit too.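

In this assay, compound 3 and compound 4 are each known only as a limit, and no step between them can be read: the limit of > 100000 nM in this assay, at which 2 of the 4 values shown sit.

The compounds shown leave open whether the change from methoxy to hydroxy shifts the value at all on the core shared by compound 3 and compound 4.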